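Swapping the amine on a thiocarbamate side chain

The compounds below may be only part of what the source reports. "The series", "measured", "known", "first", "only" and "open" are said of these compounds alone.

Compound 2 `O=c1cc(CSC(=S)N2CCCCC2)oc2cc(Cl)ccc12` reaches only a limit in a functional assay on HeLa cells (Homo sapiens) for antiproliferative activity, read by MTT assay, with a stated time of 72 h (a higher number here means a weaker inhibitor, a lower number a stronger inhibitor), namely > 25000 nM. Compound 3 `O=c1cc(CSC(=S)N2CCCCC2)oc2ccccc12` also gives only a limit in this assay, > 25000 nM. The step that the two limits leave unreadable from compound 2 to compound 3 cannot be read, since both values sit at the limit of > 25000 nM in this assay, at which 2 of the 3 values shown sit. Among the compounds with values here, compound 1 `COc1ccc2occ(CSC(=S)N(C(C)C)C(C)C)c(=O)c2c1`, which carries a diisopropylamino group on a differently substituted core, gives 5400 nM in this assay, but no single-change step links it to compound 2. Compound 4 `CC(C)N(C(=S)SCc1cc(=O)c2ccc(Cl)cc2o1)C(C)C` differs from compound 2 by diisopropylamino in place of piperidin-1-yl on a thiocarbonyl carbon. Within the data shown here, no measured step bears on this exchange, and the one step that was measured is unreadable. Compound 4 is therefore expected to give roughly 20000 nM, between 5000 nM and 60000 nM, with a real chance of again only a limit. The expected step is an at least 1.2-fold lower number from compound 2 to compound 4 (0.09 log units; that floor lies within the scatter).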

Compound 4, half-maximal inhibitory concentration: > 30000 nM
Compound 4: only a limit was reported (the forecaster's own chance of this, stated with the estimate: 50%); middle value at least 1.5-fold (0.17 log units) away from the limit.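

Compound 2 and compound 4 both give only limits in this assay, and the step between them cannot be read. The compounds shown leave open whether diisopropylamino in place of piperidin-1-yl changes activity on this shared core at all.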